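From fluoro to benzyloxycarbonyl on a shared core

The source may report more compounds than this note shows. Statements on the series, on what has been measured and on what is new or still open speak of the compounds shown alone.

Values in a functional assay on A549 cells (Homo sapiens) for antiproliferative activity, read by MTT assay, with a stated time of 48 h (on this read-out higher numbers stand for weaker inhibition and lower numbers for stronger inhibition), for the two measured compounds
- Compound 1 (`Fc1ccc2[nH]c(-c3cn(-c4ccccc4)nc3-c3ccccc3)nc2c1`) gives 1720 nM
- Compound 2 (`COc1ccc(-c2nn(-c3ccccc3)cc2-c2nc3cc(F)ccc3[nH]2)cc1`) gives 1980 nM

Only these two numbers exist so far, and they lie within the usual scatter of each other, so compound 2 stands level with compound 1. For the measured compounds named here, the one measured step, methoxy in place of hydrogen on an aromatic carbon, is a 1.2-fold higher number from compound 1 to compound 2 (0.06 log units; within the scatter) and stays within the scatter. Compound 3 (`COc1ccc(-c2nn(-c3ccccc3)cc2-c2nc3cc(C(=O)OCc4ccccc4)ccc3[nH]2)cc1`) keeps everything in compound 2 except for one exchange, benzyloxycarbonyl in place of fluoro on an aromatic carbon. Going by the values given here, the measured step happened at a different place, and no measured compound varies the group that now changes. That step therefore offers only weak guidance and no direction. With nothing pointing up or down, the expectation in this assay is no shift beyond the scatter, though with real uncertainty. The estimated change is a 1.0-fold higher number from compound 2 to compound 3 (0.00 log units; within the scatter) and could turn out either way. For compound 3 the expected value is 2000 nM with an estimated range of 500 nM to 8000 nM in this measurement.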

Compound 3, half-maximal inhibitory concentration: 11900 nM
Estimate against measurement, compound 3: 6.0-fold (0.77 log units) below; measured number outside the range, above it.
By their numbers in this assay, from the lowest: compounds 1 and 2 (each within the scatter of the next); then compound 3.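

For the compounds shown here, this is the first measured change at the aromatic carbon that carries fluoro in compound 2, and in this assay it moves the number clearly: a 6.0-fold higher number from compound 2 to compound 3 (0.78 log units; beyond the scatter), whereas the methoxy step, made at a different place, stayed within the scatter. The position therefore does not tolerate every group equally, since replacing a single fluorine atom with benzyloxycarbonyl, which brings 10 heavy atoms and a further six-membered aromatic ring, goes with weaker inhibition of the cancer cells. No measurement accompanies this result that could say why the number rises, so its cause remains unknown.

With only one exchange at this position, the compounds shown cannot separate the parts of the entering group, and they leave open whether a smaller methoxycarbonyl group or a free carboxylic acid would stay close to compound 2 or follow compound 3. As far as these compounds go, it also remains open whether the same exchange would have a similar effect on compound 1, which has hydrogen where compound 2 has methoxy.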